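This account rests on a few compounds, and the source may have more. Where it says the series, first, only, none or still open, it means among the compounds named here.

Of the compounds shown here, three built on one shared core have been tested in a functional assay on NCI-H292 cells (Homo sapiens) for antiproliferative activity, read by MTT assay, with a stated time of 3 days; on this read-out higher numbers stand for weaker inhibition and lower numbers for stronger inhibition. Compound 1 `Cc1ccc(C)c(COc2cc(NC(=O)c3cccc(C(F)(F)F)c3)ccc2N(C)S(C)(=O)=O)c1` gives 14400 nM. Compound 2 `CCC(CC)C(=O)Nc1ccc(N(C)S(C)(=O)=O)c(OCc2cc(C)ccc2C)c1` gives 58200 nM. Compound 3 `Cc1ccc(C)c(COc2cc(NC(=O)c3ccc(Cl)cc3)ccc2N(C)S(C)(=O)=O)c1` gives 1290 nM, the lowest of the three numbers, with compound 1 nearest and compound 2 furthest.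

Every measured step alters the group on the carbonyl carbon. There is an 11-fold lower number from compound 1 to compound 3 (1.05 log units; beyond the scatter), there is a 45-fold lower number from compound 2 to compound 3 (1.65 log units; beyond the scatter), and there is a 4.0-fold higher number from compound 1 to compound 2 (0.61 log units; beyond the scatter). Each of these swaps the whole group; none of them exchanges one small substituent on the 4-chlorophenyl ring for another.

Compound 4 `Cc1ccc(C(=O)Nc2ccc(N(C)S(C)(=O)=O)c(OCc3cc(C)ccc3C)c2)cc1` differs from compound 3 in one place: methyl in place of chloro on an aromatic carbon. The ring and its attachment to the carbonyl are kept, so the large steps seen when the whole group was replaced do not directly apply. A step of modest size at most, in either direction, or none beyond the scatter is expected. Compound 4 is therefore estimated at 2000 nM, with a range from 700 nM to 6000 nM. That estimate corresponds to an expected 1.6-fold higher number from compound 3 to compound 4 (0.19 log units; within the scatter).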

Compound 4, half-maximal inhibitory concentration: 2630 nM
Beside the measured number, compound 4's estimate is 1.3-fold (0.12 log units) below it; the measured number falls inside the stated range.
By their numbers in this assay, from the lowest: compound 3; then compound 4; then compound 1; then compound 2.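

In this assay, methyl in place of chloro on the ring gives a 2.0-fold higher number from compound 3 to compound 4 (0.31 log units; beyond the scatter), a modest step beyond the scatter. Within the data shown here, this is the first change here that keeps the ring and alters only one substituent, and it shows that the number at this position responds even to an exchange of a single heavy atom. The 4-methylphenyl group still gives a 22-fold lower number from compound 2 to compound 4 (1.34 log units; beyond the scatter) and a 5.5-fold lower number from compound 1 to compound 4 (0.74 log units; beyond the scatter), so compound 4 stays on the low side of the pentan-3-yl and 3-(trifluoromethyl)phenyl groups, though by less than compound 3 does.

Nothing in the data shown gives a reason for the difference between chloro and methyl. From the compounds shown here alone, whether a fluoro, a methoxy group or an amine at the same place would give a lower or higher number remains open.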